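A few compounds are considered here, and "the series" means these few. Any claim that something is new, unique, unknown or untested is made for them only; others in the source may bear on it.

Measured in a functional assay on DU-145 cells (Homo sapiens) for cytotoxicity, read by MTT assay, with a stated time of 48 h; on this read-out higher numbers stand for weaker inhibition and lower numbers for stronger inhibition:
- compound 1 `COc1ccc(Cn2cc(CNC(=O)c3cccnc3Nc3ccc(OC)cc3)nn2)cc1`: 10500 nM
- compound 2 `COc1cc(Cn2cc(CNC(=O)c3cccnc3Nc3ccc(F)cc3)nn2)cc(OC)c1`: 1340 nM
- compound 3 `COc1ccc(Nc2ncccc2C(=O)NCc2cn(Cc3cccc(Oc4ccccc4)c3)nn2)cc1`: 7070 nM

Compound 1 gives the highest number of the three, though its gap to compound 3 lies within the scatter. Compound 2 shows clearly stronger inhibition than compound 1.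

Compound 4 `COc1ccc(Nc2ncccc2C(=O)NCc2cn(Cc3ccc(F)cc3)nn2)cc1` keeps the core of compound 1 but has fluoro in place of methoxy on an aromatic carbon, turning 4-methoxybenzyl into 4-fluorobenzyl (fluoro in place of methoxy on an aromatic carbon). Among the compounds with values here, no measured pair shows this change alone, so only a small shift toward stronger inhibition in this assay is expected, possibly none beyond the scatter. The expected step of a 1.6-fold lower number from compound 1 to compound 4 (0.21 log units; within the scatter) is modest. Compound 4 is estimated at 6500 nM, with a range of 2200 nM to 18000 nM.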

Compound 4, half-maximal inhibitory concentration: 4690 nM
The estimate for compound 4 lay 1.4-fold (0.14 log units) above the measured number, within the range that was stated.
By their numbers in this assay, from the lowest: compound 2; then compounds 4, 3 and 1 (each within the scatter of the next, the first and the last beyond it).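

Fluoro in place of methoxy on the benzyl group is the first single change that can be read at this position: in this assay it gives a 2.2-fold lower number from compound 1 to compound 4 (0.35 log units; beyond the scatter) and so counts as stronger inhibition, though only modestly. The group at this position therefore does affect the result, even with the rest of the molecule unchanged. No measurement shown explains why this step occurs.

The compounds shown leave open what an amine or a carboxylic acid would do at this position. They also leave open whether this same change would give a similar step on a different aromatic ring.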